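Quinazolinone thioacetamides in rat paw edema: adding chloro

This account rests on a few compounds, and the source may have more. Where it says the series, first, only, none or still open, it means among the compounds named here.

Measured so far:
compound 1, `N#Cc1c(Cl)nc(SCC(=O)Nn2c(COc3ccc(Cl)cc3Cl)nc3ccccc3c2=O)nc1-c1ccccc1`, 68.4%
compound 2, `N#Cc1c(Nc2ccccc2)nc(SCC(=O)Nn2c(COc3ccc(Cl)cc3Cl)nc3ccccc3c2=O)nc1-c1ccccc1`, 78.1%
compound 3, `N#Cc1c(Nc2ccc(O)cc2)nc(SCC(=O)Nn2c(COc3ccc(Cl)cc3Cl)nc3ccccc3c2=O)nc1-c1ccccc1`, 59.7%

Of the compounds shown here, three sharing one core have been read in a functional assay on the whole organism (strain albino) for inhibition, with Rattus norvegicus as the target, read by paw edema, with stated times of 1 h and 3 h, at a dose of 100 mg/kg by the oral route; a higher number here means a stronger effect of the compound at the dose given, a lower number a weaker effect. Compound 3 gives the lowest of the three numbers in this assay; the step of a number 8.7 percentage points lower from compound 1 to compound 3 (within the scatter) is within the scatter, so compound 1 and compound 3 cannot be ordered, while the step of a number 18.4 percentage points lower from compound 2 to compound 3 (beyond the scatter) is beyond it. The step of a number 9.7 percentage points higher from compound 1 to compound 2 (within the scatter) is also within the scatter.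

Compound 4, `N#Cc1c(Nc2ccc(O)cc2)nc(SCC(=O)Nn2c(COc3ccc(Cl)cc3Cl)nc3ccccc3c2=O)nc1-c1ccc(Cl)cc1`, has not yet been measured in this assay. It differs from compound 3 in one place only: chloro in place of hydrogen on an aromatic carbon. Among the compounds with values here, none of the measured steps bears on this position. All three of them concern the other aromatic carbon, where chloro gave way to anilino or to (4-hydroxyphenyl)amino, or where hydroxy replaced hydrogen; nothing in the series tells how a chloro on this ring acts. Within the data shown here, with no step to lean on, a change beyond the scatter is not expected in either direction. Compound 4 is therefore estimated at 62%, with a range from 48% to 76%, which means an expected step of a number 2.3 percentage points higher from compound 3 to compound 4 (within the scatter).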

Compound 4, a percentage reported as inhibition, in the whole organism at one dose (the size of the read-out at that dose, not a potency): 91.2%
Compound 4: the middle estimate sits 29.2 percentage points below what was measured; measured number above the stated range.
By their numbers in this assay, from the lowest: compounds 3, 1 and 2 (each within the scatter of the next, the first and the last beyond it); then compound 4.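

In this assay, the change from phenyl to 4-chlorophenyl, on a six-membered aromatic ring of carbon only and para to a large group, gives a number 31.5 percentage points higher from compound 3 to compound 4 (beyond the scatter), so this ring is a place where a single chloro can move the read-out well beyond the scatter. Within the data shown here, the earlier steps all concerned the other aromatic carbon, and this is the first sign that the ring carrying chloro in compound 4 also matters for the effect at the dose given. The step is established only with (4-hydroxyphenyl)amino on the other aromatic carbon, and the compounds shown offer no measured property that could account for it.

Going by these compounds, it remains open whether the same chloro would give a step of this size alongside anilino or chloro at that other carbon, as in compound 2 and compound 1. Also open, on these data alone, is whether the effect is specific to chloro or would extend to fluoro, bromo, methyl or methoxy at the same place on the ring, or to chloro elsewhere on it.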